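Swapping the Aryl Ether for a Cyanobenzyl Arm

The source may report more compounds than this note shows. Statements on the series, on what has been measured and on what is new or still open speak of the compounds shown alone.

Compound 1, `CC(C)(C)c1ccc(Oc2ccc3c(NCCCNCc4ccco4)ccnc3c2)cc1`, 14500 nM
Compound 2, `Fc1ccc(Oc2ccc3c(NCCCNCc4ccco4)ccnc3c2)cc1`, 14500 nM
Compound 3, `COc1cccc(CNCCCNc2ccnc3cc(Oc4ccc(F)cc4)ccc23)c1O`, 14500 nM

Of the compounds shown here, three sharing one core have been measured in a physicochemical assay for solubility, with a stated time of 18 h, at pH 7.4; a lower number here means a less soluble compound, a higher number a more soluble compound. Compound 1 gives 14500 nM, compound 2 gives 14500 nM and compound 3 gives 14500 nM. Compound 2 stands level with both neighbours: the step of no change at the digits printed from compound 1 to compound 2 (within the scatter) and the step of no change at the digits printed from compound 2 to compound 3 (within the scatter) are each within the scatter, so neither the change at the aromatic carbon nor the change at the amine-bound chain carbon moved the read-out.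

Compound 4, `N#Cc1ccc(Cc2ccc3c(NCCCNCc4ccco4)ccnc3c2)cc1`, has not yet been tested in this assay. It differs from compound 2 in one place: 4-cyanobenzyl in place of 4-fluorophenoxy on an aromatic carbon. Within the data shown here, no measured step replaces an ether oxygen link with a methylene link, so the two recorded steps bear on it only indirectly, as evidence that changes at the periphery of this core have so far left solubility flat. On that basis compound 4 is expected to show no change at the digits printed from compound 2 to compound 4 (within the scatter), with no move beyond the scatter.

Compound 4 is therefore estimated at 14500 nM, with a range from 6000 nM to 30000 nM.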

Compound 4, solubility: 4200 nM
Compound 4: middle estimate off by 3.5-fold (0.54 log units), on the high side; the whole stated range lies above it.
By their numbers in this assay, from the lowest: compound 4; then compounds 1, 2 and 3 (each within the scatter of the next).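

In this assay, among these compounds, the exchange of 4-fluorophenoxy for 4-cyanobenzyl gives a 3.5-fold lower number from compound 2 to compound 4 (0.54 log units; beyond the scatter), the first step to lie beyond the scatter. The earlier steps shown here exchanged tert-butyl for fluoro on the aryl ether and furan-2-yl for 2-hydroxy-3-methoxyphenyl on the chain, whereas this one replaces the whole arm on the aromatic carbon of the fused system, so the level values of compounds 1, 2 and 3 did not mean that the read-out is insensitive to every change around the shared core. No accompanying measurement bears on why the number fell, so the step stands as an observation only.

From the compounds shown here alone, the step alters the link and the ring substituent together, with the ether oxygen giving way to a methylene and the fluoro group to a nitrile, so it remains open which of the two carries the change; 4-fluorobenzyl or 4-cyanophenoxy on the same carbon would separate them. Also open, going by these compounds, is how a carboxylic acid or an amine on that aromatic ring would read, and whether the 4-cyanobenzyl arm gives a similar step when 2-hydroxy-3-methoxyphenyl replaces furan-2-yl on the chain.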